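The compounds below may be only part of what the source reports. "The series", "measured", "known", "first", "only" and "open" are said of these compounds alone.

Measured so far:
compound 1 `Nc1ccccc1-c1cnc(C(=O)CCCCCCc2ccccc2)o1` — 750 nM
compound 2 `Nc1ccc(-c2cnc(C(=O)CCCCCCc3ccccc3)o2)cc1` — 90 nM

In an assay (Rattus norvegicus) for inhibition of Fatty-acid amide hydrolase 1 (Homo sapiens) (on this read-out higher numbers stand for weaker inhibition and lower numbers for stronger inhibition), compound 2 gives 90 nM, the lowest of the two numbers. Within the data shown here, the nearest measured compound is compound 1, and the single step known is an 8.3-fold lower number from compound 1 to compound 2 (0.92 log units; beyond the scatter), which moved the amino group from one position to another on the same ring while keeping the rest of the molecule unchanged.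

Compound 3 `COc1ccc(-c2cnc(C(=O)CCCCCCc3ccccc3)o2)cc1` differs from compound 2 by methoxy in place of amino on an aromatic carbon. Among the measured compounds shown here, no measured step bears directly on this exchange: the only step concerns where the amino group sits, not what replaces it, so nothing in the data shows how a methoxy group at that place compares with an amino group. The working expectation is therefore a step of no more than modest size in this assay, with the direction open. The estimated step is a 1.7-fold higher number from compound 2 to compound 3 (0.22 log units; within the scatter). Compound 3 is expected to give about 150 nM, with a range from 40 nM to 600 nM.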

Compound 3, inhibition constant: 100 nM
Beside the measured number, compound 3's estimate is 1.5-fold (0.18 log units) above it, within the range that was stated.
By their numbers in this assay, from the lowest: compounds 2 and 3 (each within the scatter of the next); then compound 1.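

On the six-membered aromatic ring, at the place para to a large group, methoxy stands in for amino with a 1.1-fold higher number from compound 2 to compound 3 (0.05 log units; within the scatter) in this assay; the hydrogen-bond donor of the amino group is therefore not needed to keep the number at this level. The step of a 7.5-fold lower number from compound 1 to compound 3 (0.88 log units; beyond the scatter) shows that the lower number seen with 4-aminophenyl is not confined to an amino group, since 4-methoxyphenyl also lies clearly below the 2-aminophenyl of compound 1. Nothing at hand gives a reason for either step.

Open, as far as these compounds go, is whether this tolerance extends to groups of another kind at the same place, such as a hydroxy group, a carboxylic acid or a dimethylamino group. Also open, from the compounds shown here alone, is whether the same tolerance holds with a shorter chain on the carbonyl.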